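The source may report more compounds than this note shows. Statements on the series, on what has been measured and on what is new or still open speak of the compounds shown alone.

Working notes on the series. Compound 1 `COC(=O)Cn1c(=O)c(C)cn([C@@H]2O[C@H](CO[Si](C)(C)C(C)(C)C)[C@@]3(OS(=O)(=O)C=C3N)[C@H]2O[Si](C)(C)C(C)(C)C)c1=O` and compound 2 `Cc1cn([C@@H]2O[C@H](CO[Si](C)(C)C(C)(C)C)[C@@]3(OS(=O)(=O)C=C3N)[C@H]2O[Si](C)(C)C(C)(C)C)c(=O)n(CC2CC2)c1=O` share the core and differ only at the saturated chain carbon bound to an aromatic nitrogen. In a functional assay on CCRF-CEM cells (Homo sapiens) (a lower number here means that less compound is tolerated, a higher number that more compound is tolerated), compound 1 gives > 152000 nM, which is a limit of the assay and not a number (the limit of > 152000 nM in this assay, at which 1 of the 2 values shown sits). In this assay compound 2 gives 60400 nM. Among the measured compounds shown here, the single measured step, an at least 2.5-fold lower number from compound 1 to compound 2 (0.40 log units; beyond the scatter), concerns cyclopropyl in place of methoxycarbonyl, so compound 1 is known only from its limit.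

Compound 3 `CNC(=O)Cn1c(=O)c(C)cn([C@@H]2O[C@H](CO[Si](C)(C)C(C)(C)C)[C@@]3(OS(=O)(=O)C=C3N)[C@H]2O[Si](C)(C)C(C)(C)C)c1=O` changes the end of that side chain: methylamino in place of methoxy on a carbonyl carbon. For the measured compounds named here, no measured step covers methylamino in place of methoxy on a carbonyl carbon, and the step from compound 1 to compound 2 does not bear on it. With compound 1 at the limit, a number beyond the scatter in either direction cannot be anticipated. For compound 3 the expected value in this assay is 150000 nM, with a range from 60000 nM to 300000 nM. That corresponds to an expected step of an at least 1.0-fold lower number from compound 1 to compound 3 (0.00 log units; that floor lies within the scatter), none beyond the scatter.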

Compound 3, half-maximal cytotoxic concentration: >= 250000 nM
Compound 3 was reported as a limit (the forecaster's own chance of this, stated with the estimate: 60%); at least 1.6-fold (0.22 log units) between middle value and limit.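

In this assay compound 3 stands at a limit of the assay and not at a number: the limit of >= 250000 nM in this assay, at which 1 of the 3 values shown sits.

With limits at both ends, the change from methoxy to methylamino on a carbonyl carbon cannot be read, so the methoxycarbonyl and methylcarbamoyl side chains cannot be ordered. Methylcarbamoyl in place of cyclopropyl gives an at least 4.1-fold higher number from compound 2 to compound 3 (0.61 log units; beyond the scatter), so both carbonyl-bearing side chains shown now end at limits and only the cyclopropyl side chain gives a number.

As far as these compounds go, whether that split follows the carbonyl or something specific to cyclopropyl stays open, and a carboxylic acid, a primary amide or a plain longer alkyl chain at this place would bear on it. Also open, from the compounds shown here alone, is how far compound 1 and compound 3 lie beyond their limits.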